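Swapping trifluoromethyl for methoxy on a quinoxaline dioxide core

The source may report more compounds than this note shows. Statements on the series, on what has been measured and on what is new or still open speak of the compounds shown alone.

Of the compounds shown here, three have been measured in an ADME assay on Vero cells (Chlorocebus sabaeus) for cytotoxicity, read by MTT assay, with a stated time of 72 h; a lower number here means a stronger inhibitor, a higher number a weaker inhibitor. Compound 1 `Cc1ccc(-c2c(C#N)[n+]([O-])c3cc(C(F)(F)F)ccc3[n+]2[O-])cc1` gives 0.28 ug/mL. Compound 2 `COc1ccc2c(c1)[n+]([O-])c(C#N)c(-c1ccc(C)cc1)[n+]2[O-]` differs from it by methoxy in place of trifluoromethyl on an aromatic carbon, and in this assay compound 2 gives 3.8 ug/mL; the step is a 14-fold higher number from compound 1 to compound 2 (1.13 log units; beyond the scatter). Compound 3 `COC(=O)c1ccc(-c2c(C#N)[n+]([O-])c3cc(C(F)(F)F)ccc3[n+]2[O-])cc1` carries a different group on the other ring, (methoxycarbonyl in place of methyl on an aromatic carbon), and in this assay compound 3 gives 1.93 ug/mL, so that the step is a 6.9-fold higher number from compound 1 to compound 3 (0.84 log units; beyond the scatter).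

Compound 4 `COC(=O)c1ccc(-c2c(C#N)[n+]([O-])c3cc(OC)ccc3[n+]2[O-])cc1` has not yet been measured. Going by the values given here, it differs from compound 3 by methoxy in place of trifluoromethyl on an aromatic carbon, which is the same change as the one made from compound 1 to compound 2, at the same place. Among the compounds with values here, on that single earlier step, the expectation for compound 4 in this assay is a similarly sized rise in the number, estimated as a 10-fold higher number from compound 3 to compound 4 (1.02 log units; beyond the scatter), although with only one prior example the size is uncertain. Compound 4 is therefore expected to give about 20 ug/mL, with a plausible range from 6 ug/mL to 60 ug/mL.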

Compound 4, half-maximal inhibitory concentration: 3.9 ug/mL
Compound 4: the middle estimate sits 5.1-fold (0.71 log units) above what was measured; measured number outside the range, below it.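

In this assay, methoxy in place of trifluoromethyl gives a 2.0-fold higher number from compound 3 to compound 4 (0.31 log units; beyond the scatter), so the number rises on both cores, but the size of the step does not carry over: the same change on two cores in this assay, a 14-fold higher number (1.13 log units; beyond the scatter) from compound 1 to compound 2 and a 2.0-fold higher number (0.31 log units; beyond the scatter) from compound 3 to compound 4, 6.7-fold (0.83 log units) apart, beyond the scatter of two such steps Methoxycarbonyl in place of methyl shows the same dependence on its surroundings, giving a 1.0-fold higher number from compound 2 to compound 4 (0.01 log units; within the scatter), a step within the scatter, where the core of compound 1 had shown a clear rise: the same change on two cores in this assay, a 6.9-fold higher number (0.84 log units; beyond the scatter) from compound 1 to compound 3 and a 1.0-fold higher number (0.01 log units; within the scatter) from compound 2 to compound 4, 6.7-fold (0.83 log units) apart, beyond the scatter of two such steps Across these four compounds, the size of each change depends on the group present at the other place, so neither step can be carried to a new core at its full size, though with a single pair on each side this does not show why, or whether the same holds beyond these compounds.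

Going by these compounds, it remains open how other groups would behave in the place of trifluoromethyl, such as chlorine or an amine, or in the place of methoxycarbonyl, such as a carboxylic acid. On these data alone, all four compounds also share the nitrile, so what an amide there would do to these steps is unknown.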